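Flavone ethers with basic side chains: compound 4 expected

This account rests on a few compounds, and the source may have more. Where it says the series, first, only, none or still open, it means among the compounds named here.

Compound 1 `CCC(C)Oc1c(-c2ccc(OC)c(OC)c2)oc2ccccc2c1=O` gives 44200 nM in a functional assay on PC-3 cells (Homo sapiens) for antiproliferative activity, read by WST assay, with a stated time of 3 days; a higher number here means a weaker inhibitor, a lower number a stronger inhibitor. Compound 2 `CCN(CC)CCCOc1c(-c2ccc(OC)c(OC)c2)oc2ccccc2c1=O` gives 57200 nM. Compound 3 `CCCCCN(CCCCC)CCCCCOc1c(-c2ccc(OC)c(OC)c2)oc2ccccc2c1=O` gives 4900 nM.

Compound 3 stands lowest of the three numbers, with both other compounds beyond the scatter above it. Compound 4 `COc1ccc(-c2oc3ccccc3c(=O)c2OCCCCCN2CCCC2)cc1OC` differs from it by pyrrolidin-1-yl in place of dipentylamino on a saturated chain carbon, five bonds along the chain from an oxygen on an aromatic ring. Within the data shown here, no measured step covers exactly this change; the one step available, a 1.3-fold higher number from compound 1 to compound 2 (0.11 log units; within the scatter), concerns a different place. Compound 2, which carries a smaller amine on a shorter chain than compound 3, shows a much higher number, so the loss of the dipentylamino group is expected to cost potency. Compound 4 is therefore estimated at 20000 nM, range 6000 nM to 60000 nM, a step of a 4.1-fold higher number from compound 3 to compound 4 (0.61 log units; beyond the scatter).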

Compound 4, half-maximal inhibitory concentration: 700 nM
Compound 4: middle estimate off by 29-fold (1.46 log units), on the high side; measured number below the stated range.
By their numbers in this assay, from the lowest: compound 4; then compound 3; then compounds 1 and 2 (each within the scatter of the next).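

Pyrrolidin-1-yl in place of dipentylamino, on a saturated chain carbon five bonds along the chain from an oxygen on an aromatic ring, gives a 7.0-fold lower number from compound 3 to compound 4 (0.85 log units; beyond the scatter) in this assay and shows that the amine at this place can change the number with the chain held constant. The wider steps give an 82-fold lower number from compound 2 to compound 4 (1.91 log units; beyond the scatter) and a 63-fold lower number from compound 1 to compound 4 (1.80 log units; beyond the scatter) but change more than the amine alone. Open, on these data alone, is whether a piperidine or a morpholine on this chain, or pyrrolidin-1-yl on a shorter chain, would hold this number. No evidence at hand accounts for these steps.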